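Benzyl for Methyl on the Outer Piperidine

The source may report more compounds than this note shows. Statements on the series, on what has been measured and on what is new or still open speak of the compounds shown alone.

Compound 1: `Cc1cc(Cl)cc(Cl)c1S(=O)(=O)N1CCC(N2CCC(C)CC2)CC1` gives 0.45 nM in a functional assay on HT-29 cells (Homo sapiens) for antiproliferative activity, read by CellTiter-Glo, with a stated time of 72 h; a higher number here means a weaker inhibitor, a lower number a stronger inhibitor.
Compound 2: `Cc1cc(C)c(S(=O)(=O)N2CCC(N3CCC(C)CC3)CC2)c(C)c1` gives 0.9 nM in this assay.

Both measured compounds share the sulfonyl-linked bipiperidine core of compound 1 and differ only in the aryl group on the sulfonyl. Compound 2 is the nearer starting point for the new compound, and its number in this assay lies within the scatter of compound 1, so the two cannot be told apart on these data; neither may be called the stronger of the pair.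

Compound 3, `Cc1cc(C)c(S(=O)(=O)N2CCC(N3CCC(Cc4ccccc4)CC3)CC2)c(C)c1`, keeps the trimethylphenyl sulfonyl of compound 2 and alters the terminal piperidine: phenyl in place of hydrogen on a saturated chain carbon bound to a saturated ring carbon. Among the compounds with values here, no measured pair shows this change, so its effect can only be guessed. Since both measured compounds sit deep in the sub-nanomolar range, a larger group on the outer ring is more likely to cost potency than to add to it, though by an amount that may not clear the scatter.

Compound 3 is estimated at 2.5 nM, within 0.4 nM to 15 nM, an expected step of a 2.8-fold higher number from compound 2 to compound 3 (0.44 log units; beyond the scatter).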

Compound 3, half-maximal inhibitory concentration: 3 nM
For compound 3 the middle estimate is 1.2-fold (0.08 log units) below the measured one, within the range that was stated.
By their numbers in this assay, from the lowest: compounds 1 and 2 (each within the scatter of the next); then compound 3.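

In this assay, the change of methyl to benzyl, phenyl in place of hydrogen on a saturated chain carbon bound to a saturated ring carbon, carries a 3.3-fold higher number from compound 2 to compound 3 (0.52 log units; beyond the scatter), a modest step. Within the data shown here, it is the first step read at this position, as compounds 1 and 2 both carry the methyl there and differ only in the aryl group on the sulfonyl. The position therefore takes a phenyl with its 6 heavy atoms at a measurable but limited loss, and compound 3 still gives 3 nM, though nothing in the data explains the step.

On these data alone, whether the step is tied to the aromatic ring itself stays open, and a cyclohexylmethyl group, a phenethyl chain or a benzyl bearing an amine or a carboxylic acid would each bear on that question. Also open, as far as these compounds go, is whether the same change carries a step of the same size on the aryl sulfonyl of compound 1, as this step is read only on the trimethylphenyl sulfonyl of compound 2.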